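The compounds below may be only part of what the source reports. "The series", "measured", "known", "first", "only" and "open" are said of these compounds alone.

Working notes. The core of compound 1 `CC(=O)O[C@@H]1OC(=O)[C@](Cc2ccccc2)(C(C)=O)[C@@H]1C` gives 40000 nM for compound 1 in a functional assay on HT-29 cells (Homo sapiens) for cytotoxicity, read by MTT assay; a higher number here means a weaker inhibitor, a lower number a stronger inhibitor. Compound 2 `CC(=O)CC[C@]1(C(C)=O)C(=O)O[C@@H](OC(C)=O)[C@H]1C` gives 7000 nM in this assay, a change of a 5.7-fold lower number from compound 1 to compound 2 (0.76 log units; beyond the scatter). Compound 3 `CC(=O)O[C@@H]1OC(=O)[C@](O)(C(C)=O)[C@@H]1C` returns only a limit of the assay in this assay, > 50000 nM. The two steps ending at compound 3 are therefore bounded: an at least 1.2-fold higher number from compound 1 to compound 3 (0.09 log units; that floor lies within the scatter) and an at least 7.1-fold higher number from compound 2 to compound 3 (0.85 log units; beyond the scatter), both reaching the limit noted in the limit of > 50000 nM in this assay, at which 1 of the 3 values shown sits.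

Compound 4 `CC(=O)O[C@@H]1OC(=O)[C@@H](C(C)=O)[C@@H]1C` differs from compound 3 by hydrogen in place of hydroxy on a saturated ring carbon. Within the data shown here, no measured step swaps hydroxy for hydrogen, so the size is not fixed; the steps into compound 3 show only that hydroxy sits at the weak end. Compound 4 is expected to stay near the same region, with a number no higher from compound 3 to compound 4 (the limit leaves the size open) not clearly beyond the scatter. The estimate for compound 4 in this assay is 50000 nM, ranging from 15000 nM to 150000 nM.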

Compound 4, half-maximal inhibitory concentration: > 50000 nM
Compound 4 ended at the assay's limit; the forecaster's own chance of this, stated with the estimate: 55%; the middle value lies on the limit itself.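

In this assay compound 4 gives > 50000 nM as a limit of the assay and not a number. Hydrogen in place of 2-acetylethyl on this saturated ring carbon gives an at least 7.1-fold higher number from compound 2 to compound 4 (0.85 log units; beyond the scatter) and hydrogen in place of benzyl gives an at least 1.2-fold higher number from compound 1 to compound 4 (0.09 log units; that floor lies within the scatter). The step between hydroxy and hydrogen cannot be read, so neither group ranks above the other here, and the weak end of the series now holds two compounds: the limit of > 50000 nM in this assay, at which 2 of the 4 values shown sit.

From the compounds shown here alone, how an amine, a carboxylic acid or a longer chain on this saturated ring carbon would read in this assay stays open. Going by these compounds, the true values of compound 3 and compound 4 also stay open.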